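Adding One Methoxy to Compound 2

A few compounds are considered here, and "the series" means these few. Any claim that something is new, unique, unknown or untested is made for them only; others in the source may bear on it.

Compound 1 `COc1cc(-c2ccc(-c3ccc(-c4nc5cc(C)ccc5[nH]4)cc3)cc2)cc(OC)c1OC` gives 190 nM
Compound 2 `COc1ccc(-c2ccc(-c3ccc(-c4nc5ccccc5[nH]4)cc3)cc2)cc1OC` gives 39700 nM

In a functional assay on ZR-75-1 cells (Homo sapiens) for inhibition, read by sulforhodamine B assay (a higher number here means a weaker inhibitor of growth, a lower number a stronger inhibitor of growth), compound 2 holds the higher number of the two at 39700 nM and compound 1 lies lower at 190 nM by a gap well beyond the scatter. Compound 2 is therefore the weaker inhibitor of growth in this pair.

Compound 3 `COc1cc(-c2ccc(-c3ccc(-c4nc5ccccc5[nH]4)cc3)cc2)cc(OC)c1OC` has not yet been measured. It comes from compound 2 by a single change, methoxy in place of hydrogen on an aromatic carbon. Within the data shown here, no measured step shows what this change does. The expectation therefore rests on one observation: the ring taking the new methoxy in compound 3 matches the corresponding ring of compound 1, which gives 190 nM in this assay and so sets the level to look towards. A large downward move, beyond the scatter, is expected, and it is estimated as a 66-fold lower number from compound 2 to compound 3 (1.82 log units; beyond the scatter) in size. For compound 3 the expected value is 600 nM within an estimated range of 120 nM to 4000 nM in this assay.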

Compound 3, concentration for 50% growth inhibition: 9710 nM
Compound 3: the middle estimate sits 16-fold (1.21 log units) below what was measured; the whole stated range lies below it.
By their numbers in this assay, from the lowest: compound 1; then compound 3; then compound 2.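

In this assay the new methoxy, on an aromatic carbon ortho to a methoxy group and meta to a large group, does lower the number, giving a 4.1-fold lower number from compound 2 to compound 3 (0.61 log units; beyond the scatter). That step is modest, and the larger one belongs to the other place: hydrogen in place of methyl on an aromatic carbon gives a 51-fold higher number from compound 1 to compound 3 (1.71 log units; beyond the scatter), so matching the methoxy-bearing ring of compound 1 does not by itself bring compound 3 to the level of compound 1, and among these compounds the methyl on the core carries the bigger step. Nothing available explains the size of either step.

The compounds shown leave open whether the methyl would have as large an effect without the new methoxy, which would tell whether the two steps simply add or depend on each other. They also leave open whether an ethyl or a chlorine could stand in for that methyl, and whether a hydroxy in place of the new methoxy would keep the modest step seen from compound 2.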